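Trifluoromethyl for Fluoro: Expected Protection of Compound 3

The compounds below may be only part of what the source reports. "The series", "measured", "known", "first", "only" and "open" are said of these compounds alone.

Compound 1 `CC(C(=O)N1CCN(c2ccccc2)CC1)N1C(=O)CCC1=O`: 0%
Compound 2 `CC(C(=O)N1CCN(c2ccccc2F)CC1)N1C(=O)CCC1=O`: 0%

Of the compounds shown here, two have been measured in a functional assay on the whole organism (strain Swiss) with Mus musculus as the target, in the maximal electroshock model, with a stated time of 0.5 h, at a dose of 100 mg/kg by the intraperitoneal route; on this read-out lower numbers stand for a weaker effect and higher numbers for a stronger effect at the one dose given. Compound 1 gives 0%, and compound 2 gives 0%. The step of no change at the digits printed from compound 1 to compound 2 (within the scatter) shows that putting a fluoro group onto the aromatic ring left the read-out where it was. Compound 2 therefore stands level with compound 1, both at the bottom of the scale, with no protective effect seen at the one dose given.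

Compound 3 `CC(C(=O)N1CCN(c2ccccc2C(F)(F)F)CC1)N1C(=O)CCC1=O` is the next member. It differs from compound 2 by trifluoromethyl in place of fluoro on an aromatic carbon. Among the measured compounds shown here, the only measured step that bears on this change is no change at the digits printed from compound 1 to compound 2 (within the scatter), which was flat, and both measured compounds sit at the floor of the read-out. For the measured compounds named here, a larger group on the same aromatic carbon is a further move in the same direction, and nothing measured so far points to a gain. The step of a number 5 percentage points higher from compound 2 to compound 3 (within the scatter) is therefore expected to stay within the scatter, and compound 3 is estimated to give 5% in this assay, in the range from 0% to 25%.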

Compound 3, a percentage reported as activity, at one dose (the size of the read-out at that dose, not a potency): 25%
Compound 3: the middle estimate sits 20 percentage points below what was measured; measured number inside the range.
By their numbers in this assay, from the lowest: compounds 1 and 2 (each within the scatter of the next); then compound 3.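

In this assay this aromatic carbon turns out not to be silent: fluoro had changed nothing there, yet trifluoromethyl gives a number 25 percentage points higher from compound 2 to compound 3 (beyond the scatter) and, measured against plain hydrogen, a number 25 percentage points higher from compound 1 to compound 3 (beyond the scatter) as well. Among the compounds shown here, the outcome at this position therefore depends on which group sits on it, and the two steps give the same picture whichever of the earlier compounds serves as the starting point. Trifluoromethyl, with its four heavy atoms in place of one, is the first change in this short series to lift the read-out clear of the scatter, although the gain is only modest.

On these data alone, whether this gain is special to trifluoromethyl, or would also appear with a chlorine atom, a methyl group or a methoxy group on the same carbon, remains open. No measurement at hand gives a reason why trifluoromethyl and fluoro part ways here.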